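The source may report more compounds than this note shows. Statements on the series, on what has been measured and on what is new or still open speak of the compounds shown alone.

Three compounds have so far been measured in a functional assay, with a stated time of 30 min; a higher number here means a weaker inhibitor, a lower number a stronger inhibitor:

Compound 1 `Sc1nnc(-c2cnccn2)n1/N=C/c1ccc(Cl)cc1Cl`: 81200 nM
Compound 2 `S=C(Nc1ccccc1)Nn1c(S)nnc1-c1cnccn1`: 58800 nM
Compound 3 `Fc1cccc(NC(=S)Nn2c(S)nnc2-c2cnccn2)c1`: 14000 nM

Compound 3 has the lowest of the three numbers in this assay. Going by the values given here, its nearest neighbour is compound 2, and the only measured step between two compounds that differ in one place is a 4.2-fold lower number from compound 2 to compound 3 (0.62 log units; beyond the scatter), which came from fluoro in place of hydrogen on an aromatic carbon. Among the compounds with values here, compound 1, with 81200 nM, is furthest from compound 3; the two share no single-point step, so only their two values can be compared.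

Compound 4 `Fc1ccc(NC(=S)Nn2c(S)nnc2-c2cnccn2)cc1` has not yet been measured. It differs from compound 3 by 4-fluorophenyl in place of 3-fluorophenyl on an amide-type nitrogen. Within the data shown here, no measured step moves a group from one position on a ring to another, and the one step recorded concerns adding fluorine rather than shifting it. There is therefore no basis for expecting a shift beyond the scatter, in either direction. Compound 4 is expected to give about 16000 nM, in a range from 5000 nM to 50000 nM. The expected step, a 1.1-fold higher number from compound 3 to compound 4 (0.06 log units; within the scatter), is estimated to lie within the usual scatter.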

Compound 4, half-maximal inhibitory concentration: 69200 nM
The estimate for compound 4 lay 4.3-fold (0.64 log units) below the measured number; measured number outside the range, above it.
By their numbers in this assay, from the lowest: compound 3; then compounds 2, 4 and 1 (each within the scatter of the next).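

In this assay, moving the fluorine alone, with 4-fluorophenyl in place of 3-fluorophenyl on an amide-type nitrogen, gives a 4.9-fold higher number from compound 3 to compound 4 (0.69 log units; beyond the scatter), so the earlier fluorine step did not depend only on fluorine being present. Fluoro in place of hydrogen on the aromatic carbon gives a 4.2-fold lower number from compound 2 to compound 3 (0.62 log units; beyond the scatter) in one case but a 1.2-fold higher number from compound 2 to compound 4 (0.07 log units; within the scatter) in the other, and only the 3-fluorophenyl compound stands apart from the unsubstituted phenyl compound by more than the scatter. Nothing given here explains this difference between the two fluorophenyl groups.

The compounds shown leave open whether chlorine or a methoxy group in place of the fluorine would follow the same course on either ring. They also leave open how a longer chain, such as benzyl in place of the fluorophenyl group, would fare on this nitrogen.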